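Furan-2-yl Replacing Hydrogen in a Cytotoxicity Series

This account rests on a few compounds, and the source may have more. Where it says the series, first, only, none or still open, it means among the compounds named here.

Compound 1, `CC(C)N(Cc1cccc(OCCCCCC(=O)O)c1)C(=O)c1ccccc1`: in an ADME assay on HEK293 cells (Homo sapiens) for cytotoxicity, read by CellTiter-Glo and resazurin assay, with a stated time of 72 h (a lower number here means that less compound is needed, a higher number that more compound is needed for the effect), compound 1 gives > 26000 nM, which is a limit of the assay.
Compound 2, `CC(C)Oc1cccc(-c2ccc(C(=O)N(Cc3cccc(OCCCCCC(=O)O)c3)C(C)C)cc2)c1`: in this assay compound 2 gives > 26000 nM, also a limit of the assay.
Compound 3, `CCOC(=O)CCCCCOc1cccc(CN(C(=O)c2ccccc2)C(C)C)c1`: in this assay compound 3 gives > 26000 nM, again a limit of the assay.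

Compound 3 therefore stands at the limit of this assay, and nothing places it above or below its two neighbours. The two measured steps that touch this set, a step that the two limits leave unreadable from compound 1 to compound 2 and a step that the two limits leave unreadable from compound 1 to compound 3, cannot be read in size or direction, since both ends of each sit at a limit. Among the measured compounds shown here, the only evidence on hand is the limit of > 26000 nM in this assay, at which 3 of the 3 values shown sit.

Compound 4, `CCOC(=O)CCCCCOc1cccc(CN(C(=O)c2ccc(-c3ccco3)cc2)C(C)C)c1`, differs from compound 3 in one place: furan-2-yl in place of hydrogen on an aromatic carbon. For the measured compounds named here, no measured step bears readably on that change, so no direction can be drawn from the steps themselves. Because every value shown sits at the limit of > 26000 nM in this assay, at which 3 of the 3 values shown sit, the plain expectation is that compound 4 stays in the same region. The step from compound 3 to compound 4 is expected to be a number no higher from compound 3 to compound 4 (the limit leaves the size open). In this assay compound 4 is thus estimated at 26000 nM, with a range from 10000 nM to 60000 nM, most likely reported again only as a limit.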

Compound 4, half-maximal effective concentration: > 26000 nM
Compound 4: no number, only a limit (the forecaster's own chance of this, stated with the estimate: 80%); the middle value lies on the limit itself.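

In this assay compound 3 and compound 4 both stand only at a limit, so no new step can be read between them, in size or in direction. The compounds shown leave open whether furan-2-yl in place of hydrogen changes the read-out at all.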